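The source may hold more compounds than are shown below. What is called first, only, known or untested is meant among the compounds shown, and "the series" means these compounds.

Compound 1 `C/N=C(\N)Nc1nnc(-c2ccccc2C(F)(F)F)s1` and compound 2 `CCCC/N=C(\N)Nc1nnc(-c2ccccc2C(F)(F)F)s1` share one core and differ only in the group on a saturated chain carbon bound to a double-bonded nitrogen. In a functional assay on the whole organism (Hindlimb) for inhibition, with Mus musculus as the target, with a stated time of 1 h (on this read-out lower numbers stand for an effect already at smaller amounts and higher numbers for an effect only at larger amounts of compound), compound 1 gives 44 mg/kg. In this assay compound 2 gives 225 mg/kg. Within the data shown here, the step of a 5.1-fold higher number from compound 1 to compound 2 (0.71 log units; beyond the scatter) is the only measured step so far, and it pairs the larger group with the higher number. Among the two numbers in hand, compound 2 stands highest, with compound 1 lower by that same step. Compound 3 `CN(C)CCC/N=C(\N)Nc1nnc(-c2ccccc2C(F)(F)F)s1` has not yet been measured. It differs from compound 2 by dimethylamino in place of methyl on a saturated chain carbon, three bonds along the chain from a double-bonded nitrogen. Among the measured compounds shown here, no measured step covers an exchange of this kind: the one step available changed the length of the chain, not the group at its end, so it offers little guidance here. With nothing pointing clearly either way, compound 3 is expected to land close to compound 2, the step of a 1.1-fold lower number from compound 2 to compound 3 (0.05 log units; within the scatter) being expected to stay within the scatter, though the range is kept wide. The estimate for compound 3 in this assay is 200 mg/kg, between 70 mg/kg and 600 mg/kg.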

Compound 3, dose for half-maximal effect: > 100 mg/kg
Compound 3 was reported as a limit (the forecaster's own chance of this, stated with the estimate: 10%); the middle value does not contradict the limit.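

The reading for compound 3 is a limit and not a number: the limit of > 100 mg/kg in this assay, at which 1 of the 3 values shown sits. The step between compound 2 and compound 3 cannot be read, so dimethylamino in place of methyl at the end of the chain cannot be said to raise the number, lower it or leave it unchanged in this assay. One comparison does hold: 2-(dimethylamino)ethyl in place of hydrogen on the saturated chain carbon bound to a double-bonded nitrogen gives an at least 2.2-fold higher number from compound 1 to compound 3 (0.35 log units; beyond the scatter), so compound 3 joins compound 2 in needing a larger dose than compound 1, whether or not its longer chain ends in an amine.

An exact dose for compound 3 would be needed to show what the dimethylamino group itself contributes, and the compounds shown give no way to tell chain length apart from the amine at its end. Also open, from the compounds shown here alone, is how this position would respond to an ethyl chain, or to a chain of the same length as in compound 3 that ends in a hydroxyl group, a carboxylic acid or a morpholine ring.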